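Aryl Ketone Piperazines: From Difluorophenyl to Methoxyphenyl

The source may hold more compounds than are shown below. What is called first, only, known or untested is meant among the compounds shown, and "the series" means these compounds.

Compound 3 `CCOC(=O)N1CCN(CCCOc2ccc(C(=O)c3cccc(F)c3F)cc2)CC1` holds the lowest of the three numbers in an assay on isolated protein for binding affinity to histamine H2 receptor (Homo sapiens) (a lower number here means a stronger inhibitor, a higher number a weaker inhibitor), giving 17400 nM. Compound 1 `C=C(C)C(=O)c1ccc(OCCCN2CCN(C(=O)OCC)CC2)cc1` stands nearest to it, with 22400 nM in this assay, and the step of a 1.3-fold lower number from compound 1 to compound 3 (0.11 log units; within the scatter) leaves the two indistinguishable. Compound 2 `CCOC(=O)N1CCN(CCCOc2ccc(C(=O)c3ccc(F)cc3)cc2)CC1` gives 42700 nM in this assay, and the step of a 2.5-fold lower number from compound 2 to compound 3 (0.39 log units; beyond the scatter) is the only one among the three that clears the scatter.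

Compound 4 `CCOC(=O)N1CCN(CCCOc2ccc(C(=O)c3ccc(OC)cc3)cc2)CC1` differs from compound 3 in one place: 4-methoxyphenyl in place of 2,3-difluorophenyl on a carbonyl carbon. The step that bears most directly on this change is a 2.5-fold lower number from compound 2 to compound 3 (0.39 log units; beyond the scatter), where a phenyl carrying one fluorine gave way to the 2,3-difluorophenyl; compound 4 returns to a phenyl carrying one group, here a methoxy rather than a fluorine. The step of a 1.3-fold lower number from compound 1 to compound 3 (0.11 log units; within the scatter) shows that another replacement at this carbonyl carbon moved the number very little. Compound 4 is therefore expected to sit somewhat higher than compound 3, a step of about a 2.0-fold higher number from compound 3 to compound 4 (0.30 log units; within the scatter), modest and near the edge of the scatter. Compound 4 is estimated at 35000 nM, within a range of 12000 nM to 100000 nM.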

Compound 4, inhibition constant: 8320 nM
The estimate for compound 4 lay 4.2-fold (0.62 log units) above the measured number; measured number below the stated range.
By their numbers in this assay, from the lowest: compound 4; then compounds 3, 1 and 2 (each within the scatter of the next, the first and the last beyond it).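

At the carbonyl carbon, compound 4 is the strongest of the four in this assay, with 4-methoxyphenyl in place of 2,3-difluorophenyl giving a 2.1-fold lower number from compound 3 to compound 4 (0.32 log units; beyond the scatter) and in place of 1-methylethenyl giving a 2.7-fold lower number from compound 1 to compound 4 (0.43 log units; beyond the scatter). The clearest contrast comes from methoxy in place of fluoro on an aromatic carbon, which gives a 5.1-fold lower number from compound 2 to compound 4 (0.71 log units; beyond the scatter), the largest step among these compounds, so a phenyl carrying one group can give either the highest or the lowest number here, depending on which group it carries. Nothing shown accounts for this difference.

The compounds shown leave open whether an ethoxy or a hydroxy group in place of the methoxy would lower the number further. They also leave open how a 2,3-dimethoxyphenyl group would compare with the 2,3-difluorophenyl group.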